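The source may hold more compounds than are shown below. What is called first, only, known or untested is meant among the compounds shown, and "the series" means these compounds.

Working notes on the series.

The two measured compounds share one core and differ only in the aryl group on the five-membered aromatic ring. Compound 1 `Cn1nc(-c2nnc(-c3cccc(Cl)c3)o2)c2ccccc21` carries a 3-chlorophenyl there; in a functional assay on HepG2 cells (Homo sapiens) for antiproliferative activity, read by MTT assay, with a stated time of 72 h (on this read-out higher numbers stand for weaker inhibition and lower numbers for stronger inhibition), compound 1 gives 21400 nM. Compound 2 `Cn1nc(-c2nnc(-c3ccccc3Br)o2)c2ccccc21` carries a 2-bromophenyl instead, and in this assay compound 2 gives 22300 nM. On the numbers in hand compound 2 stands highest of the two, with compound 1 nearest, and the step of a 1.0-fold higher number from compound 1 to compound 2 (0.02 log units; within the scatter) lies within the scatter, so the two values are not distinguishable.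

Compound 3 `Cn1nc(-c2nnc(-c3ccc(Cl)cc3)o2)c2ccccc21` is not yet measured. The change from compound 2 is 4-chlorophenyl in place of 2-bromophenyl on an aromatic carbon. Among the measured compounds shown here, the one measured step that bears on it, a 1.0-fold higher number from compound 1 to compound 2 (0.02 log units; within the scatter), moved the halogen and the halogen atom on the same phenyl and gave no shift beyond the scatter. Moving the chlorine to the 4-position is therefore expected to give no step beyond the scatter either, so for compound 3 the expected step is a 1.1-fold lower number from compound 2 to compound 3 (0.03 log units; within the scatter). The estimate for compound 3 in this assay is 21000 nM, with a range from 8000 nM to 55000 nM; a single measured analogue pair gives this estimate little support.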

Compound 3, half-maximal inhibitory concentration: 42000 nM
Estimate against measurement, compound 3: 2.0-fold (0.30 log units) below; measured number inside the range.
By their numbers in this assay, from the lowest: compounds 1, 2 and 3 (each within the scatter of the next).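

In this assay the 4-chlorophenyl group on the aromatic carbon of the shared core stays within the scatter of both earlier aryl groups, with a 1.9-fold higher number from compound 2 to compound 3 (0.27 log units; within the scatter) and a 2.0-fold higher number from compound 1 to compound 3 (0.29 log units; within the scatter) as the two new steps. Both are larger than the earlier step between compound 1 and compound 2, yet neither passes the scatter, so 3-chlorophenyl, 2-bromophenyl and 4-chlorophenyl cannot be told apart at this position on the present numbers. The comparison of compound 1 with compound 3 adds what the first pair could not show, a change of chlorine placement alone with the halogen held constant, and it too gives no readable difference. No independent data on these compounds accompany the values that could help interpret this result.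

The compounds shown leave open whether any replacement of these halogen-bearing phenyl groups would move the number beyond the scatter, such as a phenyl carrying an amine or a carboxylic acid, or a longer chain on that carbon. They also leave open whether 2-chlorophenyl would match 2-bromophenyl, which would separate the identity of the halogen from its place on the phenyl.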